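Swapping Bromo for Methyl on a Chromone Ether

This account rests on a few compounds, and the source may have more. Where it says the series, first, only, none or still open, it means among the compounds named here.

Of the compounds shown here, three sharing one core have been measured in an assay on microsomes for inhibition of Amine oxidase [flavin-containing] B (Homo sapiens), read by fluorescence and spectrophotometry, with a stated time of 20 min; a higher number here means a weaker inhibitor, a lower number a stronger inhibitor. Compound 1 `O=c1ccoc2ccc(OCCCc3ccccc3)cc12` gives 57 nM. Compound 2 `O=c1ccoc2ccc(OCc3ccc(Br)cc3)cc12` gives 3.3 nM. Compound 3 `O=c1ccoc2ccc(OCc3cccc(F)c3)cc12` gives 13 nM. Among these three numbers, compound 2 stands lowest, and its gaps to compound 3 and to compound 1 both lie beyond the usual scatter of this assay, so compound 2 is the strongest inhibitor of the three.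

Compound 4 `Cc1ccc(COc2ccc3occc(=O)c3c2)cc1` has not yet been measured. It differs from compound 2 in a single spot: methyl in place of bromo on an aromatic carbon. Among the compounds with values here, no pair of measured compounds here differs by such a one-spot change, so there is no directly comparable step to lean on.

The expectation is that the change from compound 2 to compound 4 produces a small weakening, the step of a 1.8-fold higher number from compound 2 to compound 4 (0.26 log units; within the scatter), which may or may not exceed the scatter. On that basis compound 4 is estimated at 6 nM, within a range of 2 nM to 20 nM.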

Compound 4, half-maximal inhibitory concentration: 6 nM
For compound 4 middle estimate and measured number coincide at the digits printed, and the stated range covers the measured number.
By their numbers in this assay, from the lowest: compounds 2 and 4 (each within the scatter of the next); then compound 3; then compound 1.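

Within this assay, placing methyl where bromo stood, on an aromatic carbon para to a large group, gives a 1.8-fold higher number from compound 2 to compound 4 (0.26 log units; within the scatter) and is the first one-spot comparison available in this set. At this position, the two groups therefore cannot be told apart by this measurement, which shows that bromine is not required for inhibition in this low range and that a single carbon can take its place. No measured property of either group is available to explain this similarity.

On these data alone, how an amine, a carboxylic acid or a methoxy group would read at this same position remains open, as does the effect of a longer chain such as propyl. Also open, as far as these compounds go, is whether this swap would give a similar step on a different compound.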